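Aryl Group Swap at a Ring Amine Nitrogen

A few compounds are considered here, and "the series" means these few. Any claim that something is new, unique, unknown or untested is made for them only; others in the source may bear on it.

Measured compounds:
compound 1 `CCCc1nc(-c2ccccc2)c(CNCCN2CCN(c3ccccc3C(F)(F)F)CC2)o1`, 54.6%
compound 2 `CCCc1nc(-c2ccccc2)c(CNCCN2CCN(c3cccc(F)c3)CC2)o1`, 62.3%

Of the compounds shown here, two have been measured in an assay on HEK293 cells for inhibition of Voltage-dependent T-type calcium channel subunit alpha-1G (Homo sapiens), read by fluorescence, tested at 10 uM; on this read-out lower numbers stand for less inhibition and higher numbers for more inhibition at the one concentration tested (going by the name of the read-out). Compound 1 gives 54.6% and compound 2 gives 62.3%. Compound 2 thus carries the upper of the two numbers, yet a number 7.7 percentage points higher from compound 1 to compound 2 (within the scatter), so the pair is not separated by this read-out.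

Compound 3 `CCCc1nc(-c2ccccc2)c(CNCCN2CCN(c3ccc(C(F)(F)F)cc3)CC2)o1` is the next step. It differs from compound 2 by 4-(trifluoromethyl)phenyl in place of 3-fluorophenyl on an amine nitrogen in a ring. Within the data shown here, the only measured step that bears on this position is the one from compound 1 to compound 2, also a swap of the aryl group on the amine nitrogen in a ring, and it stayed within the scatter. There is therefore no basis for expecting a step beyond the scatter in this assay in either direction; the expected step is a number 4.3 percentage points lower from compound 2 to compound 3 (within the scatter). For compound 3 the estimate in this assay is 58%, with a range from 40% to 76%.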

Compound 3, a percentage reported as inhibition, at one concentration (the size of the read-out at that concentration, not a potency): 58.7%
For compound 3 the middle estimate is 0.7 percentage points below the measured one, and the stated range covers the measured number.
By their numbers in this assay, from the lowest: compounds 1, 3 and 2 (each within the scatter of the next).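

In this assay, 4-(trifluoromethyl)phenyl on the amine nitrogen in a ring, in place of 3-fluorophenyl, gives a number 3.6 percentage points lower from compound 2 to compound 3 (within the scatter) and, in place of 2-(trifluoromethyl)phenyl, gives a number 4.1 percentage points higher from compound 1 to compound 3 (within the scatter). The three aryl groups tried at this position are therefore not separated by this read-out, and this now includes two compounds that carry the same trifluoromethyl group at different places on the phenyl ring. No independent measurement is available to account for these results.

From the compounds shown here alone, it remains open whether a pyridyl ring, a benzyl group or a simple methyl group on this amine nitrogen would move the number beyond the scatter. As the read-out comes from one concentration, the compounds shown also leave their relative potencies open.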